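This account rests on a few compounds, and the source may have more. Where it says the series, first, only, none or still open, it means among the compounds named here.

Values so far in a functional assay on B16 cells (Mus musculus) for inhibition; a higher number here means a weaker inhibitor, a lower number a stronger inhibitor:
- compound 1 `CC(=O)Oc1ccc(/C=C/C(=O)OC2CCCCC2)cc1OC(C)=O` gives 200 nM
- compound 2 `Cc1cccc(CNC(=O)/C=C/c2ccc(O)c(O)c2)c1` gives 3000 nM
- compound 3 `O=C(/C=C/c1ccc(O)c(O)c1)NCc1cccc(C(F)(F)F)c1` gives 1400 nM

Compound 2 has the highest of the three numbers, with compound 3 nearest to it and compound 1 furthest away. Next to be measured is compound 4 `O=C(/C=C/c1ccc(O)c(O)c1)NCc1ccc(Cl)cc1`. Its change from compound 2 is 4-chlorophenyl in place of 3-methylphenyl on a saturated chain carbon bound to an amide-type nitrogen.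

For the measured compounds named here, only one measured step bears on this change: a 2.1-fold lower number from compound 2 to compound 3 (0.33 log units; beyond the scatter), a modest step just beyond the scatter, with trifluoromethyl in place of methyl on an aromatic carbon. Compound 4 also loses that methyl, but a different group enters, so the comparison is only a loose guide. No single change connects compound 1 to compound 2, so its value offers no guidance here.

A shift in the same direction is expected in this assay, no larger than the measured step and possibly within the scatter. The estimated step is a 1.7-fold lower number from compound 2 to compound 4 (0.22 log units; within the scatter) and rests on this single comparison. For compound 4 the estimate is 1800 nM, with an expected range of 700 nM to 4500 nM.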

Compound 4, half-maximal inhibitory concentration: 1800 nM
Compound 4: middle estimate and measured number agree at the digits printed; the measured number falls inside the stated range.
By their numbers in this assay, from the lowest: compound 1; then compounds 3, 4 and 2 (each within the scatter of the next, the first and the last beyond it).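

In this assay, replacing 3-methylphenyl with 4-chlorophenyl on the saturated chain carbon bound to the amide-type nitrogen gives a 1.7-fold lower number from compound 2 to compound 4 (0.22 log units; within the scatter). This position therefore accepts a second aromatic group with the same heavy-atom count without a shift that can be told from scatter, whereas the trifluoromethyl-for-methyl exchange, a 2.1-fold lower number from compound 2 to compound 3 (0.33 log units; beyond the scatter), lies just beyond it. Nothing available here accounts for either outcome.

As far as these compounds go, compounds 2, 3 and 4 all carry a substituted phenyl at this position, so the effect of a group such as an amine, a carboxylic acid or a saturated cyclohexyl ring there remains open. Compound 1, at 200 nM, differs from the amides in more than one place, so its ester link and its acetate groups cannot be separated as contributors to its value.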